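The compounds below may be only part of what the source reports. "The series", "measured", "known", "first", "only" and "open" are said of these compounds alone.

Compound 1, `Oc1ccc(-c2nc3cc(C(F)(F)F)ccc3[nH]2)cc1`: in an ADME assay on BHK cells (Mesocricetus auratus) for cytotoxicity, read by MTT assay, with a stated time of 96 h (a lower number here means that less compound is tolerated, a higher number that more compound is tolerated), compound 1 gives > 100000 nM, which is a limit of the assay.
Compound 2, `O=[N+]([O-])c1ccc(-c2nc3cc(C(F)(F)F)ccc3[nH]2)cc1`: compound 2 gives 18000 nM.
Compound 3, `CC(=O)Nc1ccc(-c2nc3cc(C(F)(F)F)ccc3[nH]2)cc1`: compound 3 gives 53000 nM.

Among the two plain numbers, compound 3 stands highest; the step of a 2.9-fold higher number from compound 2 to compound 3 (0.47 log units; beyond the scatter) separates it from its nearest neighbour. The value of compound 1 is a limit (the limit of > 100000 nM in this assay, at which 1 of the 3 values shown sits), so its distance from compound 3 cannot be fixed beyond the floor given by an at least 1.8-fold lower number from compound 1 to compound 3 (0.27 log units; that floor lies within the scatter).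

Compound 4, `O=C(CCl)Nc1ccc(-c2nc3cc(C(F)(F)F)ccc3[nH]2)cc1`, has not yet been measured. It differs from compound 3 by chloro in place of hydrogen on a saturated chain carbon bound to a carbonyl carbon.

The measured steps all concern the substituent on the aromatic carbon of the shared core: an at least 5.5-fold lower number from compound 1 to compound 2 (0.74 log units; beyond the scatter), an at least 1.8-fold lower number from compound 1 to compound 3 (0.27 log units; that floor lies within the scatter) and a 2.9-fold higher number from compound 2 to compound 3 (0.47 log units; beyond the scatter). None of them touches a saturated chain carbon bound to a carbonyl carbon, so they bear on the step to compound 4 only by showing that changes at the periphery of this core have moved the number by modest amounts in both directions. The exchange of hydrogen for chloro on the acetamido chain is expected to lower the number in this assay by a modest amount, with a wide range, giving an expected step of a 2.9-fold lower number from compound 3 to compound 4 (0.47 log units; beyond the scatter). Compound 4 is therefore estimated to give 18000 nM, between 5000 nM and 55000 nM.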

Compound 4, half-maximal cytotoxic concentration: 22000 nM
For compound 4 the middle estimate is 1.2-fold (0.09 log units) below the measured one, within the range that was stated.
By their numbers in this assay, from the lowest: compounds 2 and 4 (each within the scatter of the next); then compound 3. At a limit, above all of these: compound 1.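

In this assay, the acetamido group proves sensitive to a change within its own chain and not only to exchange of the whole substituent on the aromatic carbon: chloro in place of hydrogen on a saturated chain carbon bound to a carbonyl carbon gives a 2.4-fold lower number from compound 3 to compound 4 (0.38 log units; beyond the scatter). This exchange of a single heavy atom removes the separation that compound 3 had from compound 2, since a 1.2-fold higher number from compound 2 to compound 4 (0.09 log units; within the scatter) lies within the scatter and leaves ((chloromethyl)carbonyl)amino and nitro on the aromatic carbon without an order in this assay. The hydroxy compound remains apart, with an at least 4.5-fold lower number from compound 1 to compound 4 (0.65 log units; beyond the scatter), but this is only a floor and not a fixed distance, as the value of compound 1 is a limit: the limit of > 100000 nM in this assay, at which 1 of the 4 values shown sits.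

The compounds shown leave open whether fluoro, bromo or a dimethylamino group on the same chain carbon would move the number as chloro does, or whether the step depends on chlorine itself. They also leave open whether chloro carried on a longer chain, such as a chloropropanoyl group in place of the (chloromethyl)carbonyl group, would give a step of similar size.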